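The compounds below may be only part of what the source reports. "The series", "measured", "known", "first", "only" and "open" are said of these compounds alone.

The shared core of compound 1 `CCOC(=O)C1=Cc2ccccc2OC1(OCc1cn(-c2cccc(OC)c2)nn1)C(F)(F)F` is carried unchanged into compound 2 `CCOC(=O)C1=Cc2ccccc2OC1(OCc1cc(-c2ccc3ccccc3c2)no1)C(F)(F)F` and compound 3 `CCOC(=O)C1=Cc2ccccc2OC1(OCc1cc(-c2ccc(OC)cc2)no1)C(F)(F)F`. In a functional assay on A549 cells (Homo sapiens) for inhibition, read by MTT assay, with a stated time of 24 h (on this read-out higher numbers stand for weaker inhibition and lower numbers for stronger inhibition), compound 1 gives > 150000 nM, which is a limit of the assay and not a number. Compound 2 gives > 150000 nM, again a limit. Compound 3 gives > 150000 nM, also a limit. Compound 1 therefore stands nowhere definite: it sits, like the other two, at the limit of > 150000 nM in this assay, at which 3 of the 3 values shown sit. Among the compounds with values here, the one step between measured compounds, a step that the two limits leave unreadable from compound 2 to compound 3, is unreadable from these values.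

Compound 4 `CCOC(=O)C1=Cc2ccccc2OC1(OCc1cn(CC(=O)Nc2cccc(F)c2)nn1)C(F)(F)F` differs from compound 1 by ((3-fluorophenyl)carbamoyl)methyl in place of 3-methoxyphenyl on an aromatic nitrogen. Within the data shown here, no measured step speaks to this change, since the limits leave a step that the two limits leave unreadable from compound 2 to compound 3 without size, and the three values together show only that every variant of this core tried so far stays at the limit. Compound 4 is therefore expected to show no readable movement, a step that the limit leaves unreadable from compound 1 to compound 4, and its estimated value in this assay is 200000 nM, within a range from 50000 nM to 1000000 nM.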

Compound 4, half-maximal inhibitory concentration: > 150000 nM
Compound 4 ended at the assay's limit (the forecaster's own chance of this, stated with the estimate: 80%); the middle value is on the limit's open side.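

No new step can be read: compound 1 and compound 4 both stand at a limit of the assay and not at a number, so the exchange between them has no readable size. The compounds shown leave open whether any change to the shared core can bring a readable value in this assay, since one reading holds throughout: the limit of > 150000 nM in this assay, at which 4 of the 4 values shown sit.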